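Compound 4: a Larger Group on the Ring Nitrogen

A few compounds are considered here, and "the series" means these few. Any claim that something is new, unique, unknown or untested is made for them only; others in the source may bear on it.

Compound 1, `Cn1cnc2c1c(=O)n(CC(=O)O)c(=O)n2C`, in a functional assay on MGC-803 cells (Homo sapiens) for inhibition, read by MTT assay, with a stated time of 48 h, tested at 20 uM (on this read-out higher numbers stand for more inhibition at the one concentration tested (going by the name of the read-out) and lower numbers for less inhibition), gives 0.8%.
Compound 2, `Cn1cnc2c1c(=O)n(CC(=O)N1CCSCC1)c(=O)n2C`, in this assay gives 5.6%.
Compound 3, `Cn1cnc2c1c(=O)n(CC(=O)N1CCN(c3ccccc3)CC1)c(=O)n2C`, in this assay gives 4.6%.

Compound 3 has the second highest of the three numbers in this assay; its nearest neighbour is compound 2 and its furthest is compound 1, and both gaps lie within the scatter. Compound 4, `Cn1cnc2c1c(=O)n(CC(=O)N1CCN(C(=O)/C=C/c3ccccc3)CC1)c(=O)n2C`, differs from compound 3 by (2-phenylethenyl)carbonyl in place of phenyl on an amine nitrogen in a ring. Among the measured compounds shown here, the only measured step, a number 4.8 percentage points higher from compound 1 to compound 2 (within the scatter), changes the group on the carbonyl carbon, not the amine nitrogen in a ring, so it bears on compound 4 only loosely; it stayed within the scatter. For the measured compounds named here, no measured step covers this kind of change. In this assay the step is therefore expected to be a number 1.4 percentage points higher from compound 3 to compound 4 (within the scatter), not beyond the scatter. Compound 4 is estimated at 6%, within -3% to 16%.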

Compound 4, a percentage reported as inhibition, at one concentration (the size of the read-out at that concentration, not a potency): 9.5%
For compound 4 the middle estimate is 3.5 percentage points below the measured one; the range from low to high includes it.
By their numbers in this assay, from the lowest: compounds 1, 3, 2 and 4 (each within the scatter of the next).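

Placing (2-phenylethenyl)carbonyl in place of phenyl on the amine nitrogen in the ring gives, in this assay, a number 4.9 percentage points higher from compound 3 to compound 4 (within the scatter). This group keeps the aromatic ring and adds a carbonyl and a double bond, yet the step shows no change that can be told from scatter at the one concentration tested. Nothing measured here offers a reason for the size of this step. Still open, on these data alone, is what other groups on that ring nitrogen would give, such as benzyl, acetyl or a longer chain ending in a carboxylic acid, and whether any of them would move the number beyond the scatter.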